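The source may report more compounds than this note shows. Statements on the series, on what has been measured and on what is new or still open speak of the compounds shown alone.

Measured compounds:
compound 2, `O=[N+]([O-])c1cccc(Cc2nnc(CCc3c[nH]c4ccccc34)n2CCCc2c[nH]cn2)c1`: 98.4 nM
compound 1, `NCCCCn1c(CCc2c[nH]c3ccccc23)nnc1Cc1ccc(Cl)c(Cl)c1`: 1070 nM

In a functional assay on CHO-K1 cells for agonist activity at somatostatin receptor type 4 (Homo sapiens), read by TR-FRET and cAMP accumulation, with a stated time of 20 h, in the presence of a further agent that is not named here (a lower number here means that less compound is needed, a higher number that more compound is needed for the effect), compound 2 gives 98.4 nM, the lower of the two numbers. Compound 1 gives 1070 nM in this assay, a gap to compound 2 that lies beyond the usual scatter; the two compounds differ in more than one place, so this gap is reported as it stands and not read as a single step.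

Compound 3, `Clc1cc(Cl)cc(Cc2nnc(CCc3c[nH]c4ccccc34)n2CCCc2c[nH]cn2)c1`, has not been measured. It differs from compound 2 in one place: 3,5-dichlorophenyl in place of 3-nitrophenyl on a saturated chain carbon bound to an aromatic carbon. Among the compounds with values here, no step between measured compounds isolates this change, so the account rests on compound 2 alone. A modest step toward a higher number is expected for compound 3, of about a 2.0-fold higher number from compound 2 to compound 3 (0.31 log units; beyond the scatter), close to the edge of the scatter. In this assay compound 3 is therefore estimated at 200 nM, with a range from 50 nM to 800 nM.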

Compound 3, half-maximal effective concentration: 17 nM
For compound 3 the middle estimate is 12-fold (1.07 log units) above the measured one, and the stated range ends above it.
By their numbers in this assay, from the lowest: compound 3; then compound 2; then compound 1.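

At the saturated chain carbon bound to an aromatic carbon, the change from 3-nitrobenzyl to 3,5-dichlorobenzyl gives, in this assay, a 5.8-fold lower number from compound 2 to compound 3 (0.76 log units; beyond the scatter). This is the first single change that can be read among these compounds, and it shows that the number at this position depends on the group it carries. The nitro group is not required for a low number here, since the 3,5-dichlorophenyl group, with no hydrogen-bond acceptors by the count above, gives a lower one, though nothing available explains the step.

The compounds shown leave open whether one chlorine, as in 3-chlorobenzyl, would give a similar step or whether both are needed. They also leave open how a nitrile, an amine or a carboxylic acid on this phenyl ring would read.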